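Acylation of the ring amine of compound 1

The source may hold more compounds than are shown below. What is called first, only, known or untested is meant among the compounds shown, and "the series" means these compounds.

Compound 1 `CCOC(=O)c1sc(-c2ccccc2)nc1N` carries a free amino group on its core. In an assay on HEK293 cells for inhibition of transient receptor potential cation channel subfamily M member 8 (Homo sapiens), read by FLIPR, with stated times of 5 min and 3 min (a lower number here means a stronger inhibitor, a higher number a weaker inhibitor), compound 1 gives only a limit of the assay, > 100000 nM, and no number; this is the limit of > 100000 nM in this assay, at which 1 of the 2 values shown sits. Compound 2 `CSc1cc(-c2ccc(Cl)cc2)[nH]n1`, built on another core, is the one measured entry with a number: compound 2 gives 977 nM in this assay. Compound 3 `CCOC(=O)c1sc(-c2ccccc2)nc1NC(=O)C(F)(F)F` differs from compound 1 by (trifluoromethyl)carbonyl in place of hydrogen on a nitrogen on an aromatic ring. Going by the values given here, no measured step covers such a change. Starting from a limit, compound 3 is expected to show no step beyond the scatter in this assay and most likely to remain at the limit; the step that the limit leaves unreadable from compound 1 to compound 3 is what this expectation means. Compound 3 is estimated at 120000 nM, within 20000 nM to 500000 nM.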

Compound 3, half-maximal inhibitory concentration: 7700 nM
The estimate for compound 3 lay 16-fold (1.19 log units) above the measured number; measured number outside the range, below it.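

In this assay, (trifluoromethyl)carbonyl in place of hydrogen on the nitrogen on the aromatic ring gives an at least 12-fold lower number from compound 1 to compound 3 (1.11 log units; beyond the scatter). This position therefore accepts an acyl group, and the free amino group is not needed for a measurable number in this series. The true size of the step stays unknown, since the starting value is a limit: the limit of > 100000 nM in this assay, at which 1 of the 3 values shown sits.

Going by these compounds, whether the change depends on the carbonyl or on the fluorines remains open; an acetyl group or a methyl group on this nitrogen would separate the two. On these data alone, the role of the ethyl ester is also open, as a carboxylic acid in its place would show.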